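From trifluoromethylphenyl to nitrophenyl on the ring nitrogen

The compounds below may be only part of what the source reports. "The series", "measured", "known", "first", "only" and "open" are said of these compounds alone.

Of the compounds shown here, three built on one shared core have been tested in an ADME assay on L02 cells (Homo sapiens) for antiproliferative activity, read by MTT assay, with a stated time of 48 h; a higher number here means a weaker inhibitor, a lower number a stronger inhibitor. Compound 1 `N#CC1=C(N)Oc2c(N)cc3nc4ccccc4nc3c2C12C(=O)N(Cc1cnnn1-c1ccccc1Cl)c1ccccc12` returned only a limit, > 50000 nM, which is the limit of > 50000 nM in this assay, at which 1 of the 3 values shown sits. Compound 2 `N#CC1=C(N)Oc2c(N)cc3nc4ccccc4nc3c2C12C(=O)N(Cc1cnnn1-c1ccccc1Br)c1ccccc12` gave 29200 nM. Compound 3 `N#CC1=C(N)Oc2c(N)cc3nc4ccccc4nc3c2C12C(=O)N(Cc1cnnn1-c1cccc(C(F)(F)F)c1)c1ccccc12` gave 38100 nM. The step of an at least 1.7-fold lower number from compound 1 to compound 2 (0.23 log units; that floor lies within the scatter) and the step of an at least 1.3-fold lower number from compound 1 to compound 3 (0.11 log units; that floor lies within the scatter) both rest on the limit of compound 1 and give only a floor, while the step of a 1.3-fold higher number from compound 2 to compound 3 (0.12 log units; within the scatter) lies within the scatter. Of the two numbers shown, compound 3 reports the larger, with compound 2 as its nearest neighbour, yet the two cannot be told apart.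

Compound 4 `N#CC1=C(N)Oc2c(N)cc3nc4ccccc4nc3c2C12C(=O)N(Cc1cnnn1-c1ccc([N+](=O)[O-])cc1)c1ccccc12` differs from compound 3 in one place: 4-nitrophenyl in place of 3-(trifluoromethyl)phenyl on an aromatic nitrogen. The measured step that bears on it most directly is a 1.3-fold higher number from compound 2 to compound 3 (0.12 log units; within the scatter), which also exchanges one substituted phenyl for another on the same aromatic nitrogen and stayed within the scatter; the step of an at least 1.3-fold lower number from compound 1 to compound 3 (0.11 log units; that floor lies within the scatter) changes the same position but, starting from a limit, sets only a floor. On this evidence the exchange at the aromatic nitrogen has not yet moved this assay's read-out. Compound 4 is therefore expected to show no step beyond the scatter, a 1.1-fold lower number from compound 3 to compound 4 (0.02 log units; within the scatter). The half-maximal inhibitory concentration of compound 4 is estimated at 36000 nM, within a range from 15000 nM to 85000 nM.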

Compound 4, half-maximal inhibitory concentration: > 50000 nM
Compound 4: only a limit was reported; the forecaster's own chance of this, stated with the estimate: 30%; middle value at least 1.3-fold (0.14 log units) from the limit.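

In this assay compound 4 returns only a limit, > 50000 nM, and it is the second aryl group on this aromatic nitrogen, after that of compound 1, to end there: the limit of > 50000 nM in this assay, at which 2 of the 4 values shown sit. Set against the two compounds with numbers, the exchange to 4-nitrophenyl gives an at least 1.3-fold higher number from compound 3 to compound 4 (0.11 log units; that floor lies within the scatter) and an at least 1.7-fold higher number from compound 2 to compound 4 (0.23 log units; that floor lies within the scatter), so the true steps may be larger, but these floors do not yet show that this position can move the read-out beyond the scatter. The step between compound 1 and compound 4 cannot be read, as both ends are limits, so the two compounds can be neither ranked nor called equal, and the four aryl groups shown fall into two with numbers and two without.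

The compounds shown leave open how far the values of compound 1 and compound 4 lie past the limit, and so whether any exchange at this nitrogen has a real effect in this assay. They also leave open whether a phenyl carrying an amine or a carboxylic acid in the place of the nitro group would return a number, and where that number would fall.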